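The source may hold more compounds than are shown below. What is called first, only, known or untested is meant among the compounds shown, and "the series" means these compounds.

Compound 2 `CC[N+]1(CCCCCCCOc2ccc(-n3cc(C(=O)Nc4cc(F)cc(F)c4)c(=O)c4ccc(N(C)C)nc43)cc2Cl)CCCC1` gives 23.5% in an assay on LX2 cells for inhibition of COL1A1 promoter (Homo sapiens), read by a luciferase reporter, with a stated time of 24 h, tested at 50 uM; a higher number here means a stronger effect of the compound at the concentration tested, a lower number a weaker effect. Compound 1 `CN(C)c1ccc2c(=O)c(C(=O)Nc3cc(F)cc(F)c3)cn(-c3ccc(OCCCCCCC[N+]45CCN(CC4)CC5)c(Cl)c3)c2n1` gives 20.5% in this assay. On these two numbers compound 2 stands highest, with compound 1 nearest, and the difference a number 3 percentage points higher from compound 1 to compound 2 (within the scatter) lies within the scatter, so the two cannot be ordered. Compound 3 `CN(C)c1ccc2c(=O)c(C(=O)Nc3cc(F)cc(F)c3)cn(-c3ccc(OCCCCCCC[N+](C)(C)C4CCCCC4)c(Cl)c3)c2n1` has not yet been measured. It differs from compound 2 in that (a group of 9 heavy atoms (8 carbon, 1 nitrogen; one six-membered non-aromatic ring of carbon only) in place of a group of 7 heavy atoms (6 carbon, 1 nitrogen; one five-membered non-aromatic ring with 1 hetero atom), on a saturated chain carbon, seven bonds along the chain from an oxygen on an aromatic ring). Among the compounds with values here, one measured step bears on this change, as it alters the group at the same place, on a saturated chain carbon seven bonds along the chain from an oxygen on an aromatic ring, and that step was a number 3 percentage points higher from compound 1 to compound 2 (within the scatter). Because a number 3 percentage points higher from compound 1 to compound 2 (within the scatter) stayed within the scatter, no step beyond the scatter is expected for compound 3 in this assay, that is a number 1.5 percentage points lower from compound 2 to compound 3 (within the scatter). Compound 3 is therefore estimated at 22%, with a range from 10% to 34%.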

Compound 3, a percentage reported as inhibition, at one concentration (the size of the read-out at that concentration, not a potency): 86.2%
Beside the measured number, compound 3's estimate is 64.2 percentage points below it; measured number above the stated range.
By their numbers in this assay, from the lowest: compounds 1 and 2 (each within the scatter of the next); then compound 3.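

At this place, on a saturated chain carbon seven bonds along the chain from an oxygen on an aromatic ring, the earlier exchange had stayed within the scatter in this assay, but the group with one six-membered non-aromatic ring of carbon only now gives a number 62.7 percentage points higher from compound 2 to compound 3 (beyond the scatter). The same group gives a number 65.7 percentage points higher from compound 1 to compound 3 (beyond the scatter), so the position is not indifferent to the group it carries, even though the leaving and entering groups both have net charge +1 and neither has hydrogen-bond donors or acceptors. Nothing available explains this difference.

The compounds shown leave open whether the ring of carbon only is what matters, as a cyclopentyl or phenyl ring on the same nitrogen would test. They also leave open how a shorter or longer chain would behave with this group.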